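The compounds below may be only part of what the source reports. "The series", "measured", "known", "first", "only" and "open" are said of these compounds alone.

Measured so far in a functional assay on RBL-2H3 cells (Rattus norvegicus) for inhibition; a lower number here means a stronger inhibitor, a higher number a weaker inhibitor:
- compound 1 `Cc1csc(N/C(S)=N/[C@@H](C)c2cccc3ccccc23)n1`: 83200 nM
- compound 2 `C[C@@H](/N=C(\S)Nc1nc2ccccc2s1)c1cccc2ccccc12`: 18900 nM
- compound 3 `CCOC(=O)Cc1csc(/N=C(\S)N[C@H](C)c2cccc3ccccc23)n1`: 2 nM

Compound 1 has the highest number of the three, and its nearest neighbour is compound 2; compound 3 lies far away at the low end. Compound 4 `C[C@H](/N=C(\S)Nc1nccs1)c1cccc2ccccc12` has not yet been measured. It differs from compound 1 in one place: hydrogen in place of methyl on an aromatic carbon. Going by the values given here, the change is small, and no measured pair here shows what such a change does. The step in this assay is therefore expected to be a 1.4-fold higher number from compound 1 to compound 4 (0.16 log units; within the scatter), within the scatter or modestly weaker. Compound 4 is estimated to give 120000 nM, with a range from 25000 nM to 600000 nM.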

Compound 4, half-maximal inhibitory concentration: > 100000 nM
Compound 4: no number, only a limit; the forecaster's own chance of this, stated with the estimate: 30%; the middle value does not contradict the limit.
By their numbers in this assay, from the lowest: compound 3; then compound 2; then compound 1. At a limit, above all of these: compound 4.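

Compound 4 gives only a limit in this assay, not a number: the limit of > 100000 nM in this assay, at which 1 of the 4 values shown sits. On this aromatic carbon, next to the ring nitrogen, hydrogen in place of methyl gives an at least 1.2-fold higher number from compound 1 to compound 4 (0.07 log units; that floor lies within the scatter). Going by these compounds alone, this is the first direct look at the position: hydrogen brings no measurable gain in strength here, though the true size of the step cannot be read from a limit. Still open, going by these compounds, is what an amine, a carboxylic acid or a longer chain in place of the methyl would do in this assay.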